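The source may report more compounds than this note shows. Statements on the series, on what has been measured and on what is new or still open speak of the compounds shown alone.

In a functional assay on HEK293 cells for antagonist activity at metabotropic glutamate receptor 5 (Homo sapiens), read by FLIPR and calcium flux (a higher number here means a weaker inhibitor, a lower number a stronger inhibitor), compound 1 `O=C(Cc1ccccn1)N[C@H]1CCC[C@H](NC(=O)c2cccc(Cl)c2)C1` reaches only the limit of the assay, recorded as > 10000 nM. Compound 2 `N#Cc1cccc(C(=O)N[C@@H]2CCC[C@@H](C(=O)Nc3ccccn3)C2)c1` likewise gives no number in this assay, only the limit > 10000 nM. Compound 2 therefore stands at the limit, where both recorded values sit (the limit of > 10000 nM in this assay, at which 2 of the 2 values shown sit). Compound 3 `O=C(N[C@@H]1CCC[C@@H](C(=O)Nc2ccccn2)C1)c1cccc(Cl)c1` differs from compound 2 by chloro in place of cyano on an aromatic carbon. Among the measured compounds shown here, no measured pair shows this change, so no step size is known from the data. Compound 3 is expected to remain at the limit, with an estimated step that the limit leaves unreadable from compound 2 to compound 3. Compound 3 is estimated at 15000 nM, between 5000 nM and 50000 nM.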

Compound 3, half-maximal inhibitory concentration: 5000 nM
Beside the measured number, compound 3's estimate is 3.0-fold (0.48 log units) above it, and the stated range covers the measured number.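

With chloro in place of cyano on an aromatic carbon, meta to a large group, this assay shows an at least 2.0-fold lower number from compound 2 to compound 3 (0.30 log units; that floor lies within the scatter). Compound 3 thus gives the first number rather than a limit among the compounds shown, though the change itself is only bounded and that bound does not clear the usual scatter. The true size of the step stays unread, since most values shown remain limits: the limit of > 10000 nM in this assay, at which 2 of the 3 values shown sit.

The compounds shown leave open how a methoxy group, an amine or a carboxylic acid at this place would read, and whether any such group would move the number further than chloro.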